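This account rests on a few compounds, and the source may have more. Where it says the series, first, only, none or still open, it means among the compounds named here.

Compound 3 `Cc1c(NC(=O)OC(C)C)[n+]([O-])c2cc(Cl)ccc2[n+]1[O-]` carries a chloro group on its core, and in a functional assay on HepG2 cells (Homo sapiens) for inhibition, read by sulforhodamine B assay, with a stated time of 48 h (a higher number here means a weaker inhibitor, a lower number a stronger inhibitor), compound 3 gives > 10 ug/mL, which is a limit of the assay and not a number. Where compound 3 stands is thus given only by the limit of > 10 ug/mL in this assay, at which 1 of the 3 values shown sits. Going by the values given here, the two other compounds measured so far are compound 1 `COc1ccc2c(c1)[n+]([O-])c(C(=O)N=[N+]=[N-])c(C)[n+]2[O-]`, which in this assay gives 3.61 ug/mL, and compound 2 `COc1ccc(NC(=O)Nc2c(C)[n+]([O-])c3ccc(OC)cc3[n+]2[O-])cc1`, which in this assay gives 6 ug/mL. Compound 4 `COc1ccc2c(c1)[n+]([O-])c(NC(=O)OC(C)C)c(C)[n+]2[O-]` has not yet been measured. It differs from compound 3 in one place: methoxy in place of chloro on an aromatic carbon. Among the compounds with values here, no measured pair shows this exact exchange, so the size of the step in this assay is unknown from the data; a step no larger than the usual scatter, in either direction, seems as likely as anything else, and the result may again come back only as a limit. Compound 4 is therefore expected to give about 10 ug/mL, between 4 ug/mL and 25 ug/mL. The step of a number no higher from compound 3 to compound 4 (the limit leaves the size open) is what this estimate means.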

Compound 4, half-maximal inhibitory concentration: 6 ug/mL
For compound 4 the middle estimate is 1.7-fold (0.22 log units) above the measured one; measured number inside the range.
By their numbers in this assay, from the lowest: compounds 1, 2 and 4 (each within the scatter of the next). At a limit, above all of these: compound 3.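

In this assay, methoxy in place of chloro on an aromatic carbon brings an at least 1.6-fold lower number from compound 3 to compound 4 (0.22 log units; that floor lies within the scatter), so this position now has a reading that is a number on the methoxy side. That step can be read only as a floor, because the value for compound 3 is a limit of the assay and not a number: the limit of > 10 ug/mL in this assay, at which 1 of the 4 values shown sits. With methoxy on the core, isopropoxy in place of (4-methoxyphenyl)amino on a carbonyl carbon gives no change at the digits printed from compound 2 to compound 4 (within the scatter), and the exchange on an aromatic carbon gives a 1.7-fold higher number from compound 1 to compound 4 (0.22 log units; within the scatter), so these three methoxy compounds cannot be ordered.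

On these data alone, the true size of the step from chloro stays open. So does the outcome with a methyl, a fluoro or an amine on that aromatic carbon, or with a longer chain in place of isopropoxy.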